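The source may hold more compounds than are shown below. What is called first, only, known or untested is meant among the compounds shown, and "the series" means these compounds.

Measured so far, in a functional assay on HeLa cells (Homo sapiens) for antiproliferative activity, read by XTT assay, with a stated time of 72 h; on this read-out lower numbers stand for stronger inhibition and higher numbers for weaker inhibition:
- compound 1 `C=C(C)CCC[C@]1(C)C2=CCC[C@](C)(C[C@@H](O)c3ccoc3)[C@H]2CC[C@H]1C` gives 59400 nM
- compound 2 `C=C(C)CC[C@]1(C)C2=CCC[C@](C)(C[C@@H](OC(C)=O)C3=CC(=O)OC3O)[C@H]2CC[C@H]1C` gives 6700 nM

Compound 1 stands at the highest of the two numbers; compound 2 lies beyond the scatter below it. Compound 3 `C=C(C)CCC[C@]1(C)C2=CCC[C@](C)(C[C@H](O)C3=CC(=O)OC3O)[C@H]2CC[C@H]1C` differs from compound 1 in one place: a group of 9 heavy atoms (5 carbon, 4 oxygen; one five-membered non-aromatic ring with 1 hetero atom) in place of a group of 7 heavy atoms (5 carbon, 2 oxygen; one five-membered aromatic ring with 1 hetero atom), on a saturated chain carbon bound to a saturated ring carbon. The entering group, a five-membered non-aromatic ring with 1 hetero atom, is also present in compound 2, whose number is lower than that of compound 1. On that basis compound 3 is expected to give a lower number than compound 1, a step of about a 6.6-fold lower number from compound 1 to compound 3 (0.82 log units; beyond the scatter). The estimate for compound 3 is 9000 nM, in a range from 2500 nM to 30000 nM.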

Compound 3, half-maximal inhibitory concentration: 3800 nM
Compound 3: middle estimate off by 2.4-fold (0.37 log units), on the high side; the measured number falls inside the stated range.
By their numbers in this assay, from the lowest: compounds 3 and 2 (each within the scatter of the next); then compound 1.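

For the compounds shown here, compounds 1 and 3 give the first comparison in which only one place changes. In this assay, replacing (furan-3-yl)(hydroxy)methyl with the group holding a five-membered non-aromatic ring, on a saturated chain carbon bound to a saturated ring carbon, gives a 16-fold lower number from compound 1 to compound 3 (1.19 log units; beyond the scatter). This shows that the group at this place strongly affects the read-out, but nothing measured here explains the step.

As far as these compounds go, it remains open whether the intact ring is needed, or whether a simple carboxylic acid at this place would give a similar number.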